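Nitro in place of chloro on the core of compound 1

A few compounds are considered here, and "the series" means these few. Any claim that something is new, unique, unknown or untested is made for them only; others in the source may bear on it.

In a functional assay on the whole organism (Hindlimb, strain albino) with Mus musculus as the target, in the maximal electroshock model, with a stated time of 0.5 h (on this read-out higher numbers stand for an effect only at larger amounts of compound and lower numbers for an effect already at smaller amounts), compound 1 (`COc1ccc(C2CC(Nc3nc4ccc(Cl)cc4s3)=NN2C(C)=O)cc1O`) gives 127 umol/kg and shares the low end of the three numbers with compound 2 (`CC(=O)N1N=C(Nc2nc3ccc(Cl)cc3s2)CC1c1ccccc1`) at 161 umol/kg in a pair within the scatter. Compound 3 (`COc1ccc(/C=C/C(=O)Nc2nc3ccc([N+](=O)[O-])cc3s2)cc1O`) gives 372 umol/kg and stands apart from compound 1 by more than the scatter.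

Compound 4 (`COc1ccc(C2CC(Nc3nc4ccc([N+](=O)[O-])cc4s3)=NN2C(C)=O)cc1O`) is not yet measured. It keeps the core of compound 1 with one change, nitro in place of chloro on an aromatic carbon and no other difference.

Among the measured compounds shown here, the only measured step, a 1.3-fold higher number from compound 1 to compound 2 (0.10 log units; within the scatter), lies at another place and says nothing direct about this change. Compound 3 at 372 umol/kg also carries nitro but differs from compound 1 elsewhere, so it offers only a weak hint toward a higher number. The step expected in this assay is therefore small and within the scatter: a 1.4-fold higher number from compound 1 to compound 4 (0.15 log units; within the scatter) as the working figure. The estimate for compound 4 is 180 umol/kg (expected range 85 umol/kg to 380 umol/kg).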

Compound 4, dose for half-maximal effect: 178 umol/kg
Beside the measured number, compound 4's estimate is 1.0-fold (0.00 log units) above it; the range from low to high includes it.
By their numbers in this assay, from the lowest: compounds 1, 2 and 4 (each within the scatter of the next); then compound 3.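

In this assay, among the compounds shown here, nitro in place of chloro on this aromatic carbon gives a 1.4-fold higher number from compound 1 to compound 4 (0.15 log units; within the scatter) and so stays within the scatter, which is the first direct reading at this position of the core. Together with the step at the saturated ring carbon, a 1.3-fold higher number from compound 1 to compound 2 (0.10 log units; within the scatter), this means that neither of the two single changes read so far on the core of compound 1 moves the number beyond the scatter. No data at hand speak to the reason for this result.

As far as these compounds go, whether an amine or a carboxylic acid on this aromatic carbon would also stay within the scatter remains open. Also open, from the compounds shown here alone, is whether nitro in place of chloro gives a similar step when phenyl stands on the saturated ring carbon, as in compound 2.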